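The source may report more compounds than this note shows. Statements on the series, on what has been measured and on what is new or still open speak of the compounds shown alone.

Measured in a functional assay on DLD-1 cells (Homo sapiens) for cytotoxicity, read by WST assay, with a stated time of 72 h; on this read-out higher numbers stand for weaker inhibition and lower numbers for stronger inhibition:
- compound 1 `COc1cc2c(Nc3nc4ccc(C(=O)Nc5c(C)cc(C)cc5C)cc4s3)ncnc2cc1OCCCN1CCC(C)CC1`: 7000 nM
- compound 2 `COc1cc2c(Nc3nc4ccc(C(=O)Nc5c(C)cccc5C)cc4s3)ncnc2cc1OCCCN1CCCC1`: > 100000 nM (a limit)
- compound 3 `COc1cc2c(Nc3nc4ccc(C(=O)Nc5c(C)cc(C)cc5C)cc4s3)ncnc2cc1OCCCN1CCCCC1C`: 5700 nM

Compound 1, at 7000 nM, has one close neighbour among the numbers, as the step is a 1.2-fold lower number from compound 1 to compound 3 (0.09 log units; within the scatter). Compound 2 gives > 100000 nM, which is a limit of the assay and not a number.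

Compound 4 `COc1cc2c(Nc3nc4ccc(C(=O)Nc5c(C)cccc5C)cc4s3)ncnc2cc1OCCCN1CCC(C)CC1` has hydrogen in place of methyl on an aromatic carbon of compound 1, meta to two methyl groups and para to a large group, so that 2,4,6-trimethylphenyl becomes 2,6-dimethylphenyl: hydrogen in place of methyl on an aromatic carbon.

Among the measured compounds shown here, no measured step touches this place. The only one, a 1.2-fold lower number from compound 1 to compound 3 (0.09 log units; within the scatter), is 2-methylpiperidin-1-yl in place of 4-methylpiperidin-1-yl and bears on the change only indirectly. With so little to go on, no step beyond the scatter is expected in this assay, though the uncertainty is wide and leans towards weaker inhibition. The expected step is a 1.3-fold higher number from compound 1 to compound 4 (0.11 log units; within the scatter). For compound 4 the estimated value is 9000 nM, with an expected range of 2500 nM to 40000 nM.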

Compound 4, half-maximal inhibitory concentration: > 100000 nM
Compound 4 ended at the assay's limit; the forecaster's own chance of this, stated with the estimate: 12%; middle value at least 11-fold (1.04 log units) away from the limit.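

In this assay, among the compounds shown here, taking away the single methyl group para to a large group, so that 2,4,6-trimethylphenyl becomes 2,6-dimethylphenyl, gives an at least 14-fold higher number from compound 1 to compound 4 (1.15 log units; beyond the scatter). For the compounds shown here, this is the first sign that this position matters: the change of one heavy atom carries compound 4 to a limit, whereas the only earlier readable step, on the piperidine side, stayed within the scatter. The step between compound 2 and compound 4 cannot be read, as the values of both compounds are limits and not numbers: the limit of > 100000 nM in this assay, at which 2 of the 4 values shown sit.

As far as these compounds go, whether an ethyl, methoxy or chloro group in this place would keep a measurable value remains open. So does whether pyrrolidin-1-yl on the chain would give a readable number alongside 2,4,6-trimethylphenyl.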